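Replacing the 4-bromophenyl group on the shared core: cyclotropyl step

A few compounds are considered here, and "the series" means these few. Any claim that something is new, unique, unknown or untested is made for them only; others in the source may bear on it.

The three measured compounds share one core and differ only in the group on an aromatic carbon of the five-membered aromatic ring with 3 nitrogen. In an ADME assay on HEK293 cells (Homo sapiens) for cytotoxicity, read by sulforhodamine B assay, with a stated time of 48 h, tested at 10 uM (a lower number here means less inhibition, a higher number more inhibition at the concentration tested (going by the name of the read-out)), compound 1 `COc1nc2ccc(Br)cc2cc1C(c1ccccc1)n1cc(-c2ccc(Br)cc2)nn1` gives 6.28%. Compound 2 `CCCCCCc1cn(C(c2ccccc2)c2cc3cc(Br)ccc3nc2OC)nn1` gives -3.17% in this assay, and compound 3 `COc1nc2ccc(Br)cc2cc1C(c1ccccc1)n1cc(-c2ccccc2F)nn1` gives 3.97%. Compound 1 holds the highest of the three numbers, but both of its steps fall within the scatter: a number 9.5 percentage points lower from compound 1 to compound 2 (within the scatter) and a number 2.3 percentage points lower from compound 1 to compound 3 (within the scatter). The remaining pair is also flat, a number 7.1 percentage points higher from compound 2 to compound 3 (within the scatter). None of the three exchanges at this position has moved the read-out beyond repeat-measurement noise.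

Compound 4 `COc1nc2ccc(Br)cc2cc1C(c1ccccc1)n1cc(C2CC2)nn1` is the next entry, differing from compound 1 by cyclopropyl in place of 4-bromophenyl on an aromatic carbon. The step bearing most directly on it is the replacement of 4-bromophenyl with hexyl, from compound 1 to compound 2, which was within the scatter; the 2-fluorophenyl step from compound 1 to compound 3 was likewise flat. The expectation for this assay is therefore no step beyond the scatter, with a slight downward lean, a number 4.3 percentage points lower from compound 1 to compound 4 (within the scatter). Compound 4 is thus estimated at 2%, with a range from -8% to 12%.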

Compound 4, a percentage reported as inhibition, at one concentration (the size of the read-out at that concentration, not a potency): 8.22%
Compound 4: middle estimate off by 6.2 percentage points, on the low side; the measured number falls inside the stated range.
By their numbers in this assay, from the lowest: compounds 2, 3, 1 and 4 (each within the scatter of the next, the first and the last beyond it).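

In this assay, putting a three-membered non-aromatic ring in place of a six-membered aromatic ring on this aromatic carbon leaves the number flat (a number 1.9 percentage points higher from compound 1 to compound 4 (within the scatter)), and the exchange of 2-fluorophenyl for cyclopropyl is flat as well (a number 4.3 percentage points higher from compound 3 to compound 4 (within the scatter)), so among the compounds shown an aromatic ring at this position is not required to keep the read-out in this range. The position also gives its first step beyond the scatter, though a modest one (a number 11.4 percentage points higher from compound 2 to compound 4 (beyond the scatter)), but this holds for the exchange of hexyl for cyclopropyl alone, while compound 1 and compound 3 each stay within the scatter of both compound 2 and compound 4, so no ordering of the groups follows from it. Nothing in hand accounts for this single step beyond the scatter, and no property of either group can be tied to it.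

Still open is how a basic amine such as a dimethylaminomethyl group or a carboxylic acid on this aromatic carbon would read in this assay, since all four groups shown carry no hydrogen-bond donors or acceptors. Also open, as far as these compounds go, is whether a butyl chain, shorter than hexyl, would read with the hexyl compound or with the cyclopropyl compound.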